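The source may report more compounds than this note shows. Statements on the series, on what has been measured and on what is new or still open speak of the compounds shown alone.

Measured in an assay for inhibition of Indoleamine 2,3-dioxygenase 1 (Homo sapiens), with stated times of 10 min and 60 min, tested at 100 uM; a higher number here means a stronger effect of the compound at the concentration tested, a lower number a weaker effect:
compound 1 `O=C(O)CNc1cccc(CNc2cc(C(F)(F)F)cc3[nH]ncc23)c1`, 8%
compound 2 `O=[N+]([O-])c1ccc(CNc2cc(Br)cc3[nH]ncc23)cc1`, 87%

For the measured compounds named here, compound 1 has the lowest of these two numbers; compound 2 lies higher by a margin beyond the usual scatter, but the two compounds differ in more than one place, so no single step links them and their values simply stand side by side. Compound 3 `OC1CCCC(Nc2cccc(CNc3cc(C(F)(F)F)cc4[nH]ncc34)c2)C1` has not yet been measured in this assay. It differs from compound 1 in a single place: 3-hydroxycyclohexyl in place of carboxymethyl on a nitrogen on an aromatic ring. Going by the values given here, no measured pair shows this particular change, so its effect can only be guessed. Starting from the low reading of compound 1 8%, the change is expected to bring a moderate rise, a number 27 percentage points higher from compound 1 to compound 3 (beyond the scatter), though an outcome within the scatter is quite possible. For compound 3 the estimated value is 35%, with a range from 5% to 75%.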

Compound 3, a percentage reported as inhibition, at one concentration (the size of the read-out at that concentration, not a potency): 2%
Compound 3: middle estimate off by 33 percentage points, on the high side; measured number below the stated range.
By their numbers in this assay, from the lowest: compounds 3 and 1 (each within the scatter of the next); then compound 2.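

In this assay, 3-hydroxycyclohexyl in place of carboxymethyl on a nitrogen on an aromatic ring gives a number 6 percentage points lower from compound 1 to compound 3 (within the scatter). For the compounds shown here, this is the first single-place comparison at this position, and it shows that exchanging a group with no ring for a larger one with a six-membered carbon ring does not separate the two compounds in this assay, while each carries one hydrogen-bond donor and one hydrogen-bond acceptor. No measured evidence bears on why this exchange leaves the two readings within the scatter. Going by these compounds, whether a plain amine, a simple methyl group or a longer carbon chain on this nitrogen would read any differently remains open. Also open, on these data alone, is whether any group at this position can move the reading on the core of compound 1.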